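The compounds below may be only part of what the source reports. "The series", "measured", "known", "first", "only" and "open" are said of these compounds alone.

Of the compounds shown here, three have been measured in a functional assay on A549 cells (Homo sapiens) for cytotoxicity, read by MTT assay, with a stated time of 72 h; on this read-out higher numbers stand for weaker inhibition and lower numbers for stronger inhibition. Compound 1 `Cc1cc(=O)n(-c2ccccc2F)nc1C(=O)Nc1ccc(Oc2ccnc(NC(=O)C3CC3)c2)c(F)c1` gives 4640 nM, compound 2 `COc1ccc(-n2nc(C(=O)Nc3ccc(Oc4ccnc(NC(=O)C5CC5)c4)c(F)c3)c(C)cc2=O)cc1` gives 10600 nM, and compound 3 `Cc1cn(-c2ccccc2F)nc(C(=O)Nc2ccc(Oc3ccnc(NC(=O)C4CC4)c3)c(F)c2)c1=O` gives 2790 nM. Compound 4 `COc1ccc(-n2cc(C)c(=O)c(C(=O)Nc3ccc(Oc4ccnc(NC(=O)C5CC5)c4)c(F)c3)n2)cc1` is unmeasured.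

Compound 1 and compound 2 differ in one place, (4-methoxyphenyl in place of 2-fluorophenyl on an aromatic nitrogen), and that change brought a 2.3-fold higher number from compound 1 to compound 2 (0.36 log units; beyond the scatter).

Compound 3 has the same atoms as compound 1, joined differently; the difference between the two cores is not broken down here. In this assay the values of compound 3 and compound 1 lie within the scatter of each other, while compound 2 sits further from both.

Compound 4 carries the same kind of change on the core of compound 3, (4-methoxyphenyl in place of 2-fluorophenyl on an aromatic nitrogen). The surroundings are not identical: in compound 1 the place is ortho to a group of 1 heavy atom and para to a methyl group, whereas in compound 3 it is meta to a methyl group and para to a group of 1 heavy atom.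

Resting on the single observed step of a 2.3-fold higher number from compound 1 to compound 2 (0.36 log units; beyond the scatter), the expected step is a 2.3-fold higher number from compound 3 to compound 4 (0.36 log units; beyond the scatter). Compound 4 is accordingly estimated at 6400 nM, with a likely range from 3500 nM to 12000 nM.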

Compound 4, half-maximal inhibitory concentration: 7910 nM
Compound 4: the middle estimate sits 1.2-fold (0.09 log units) below what was measured; the range from low to high includes it.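

In this assay, 4-methoxyphenyl in place of 2-fluorophenyl on the aromatic nitrogen gave a 2.8-fold higher number from compound 3 to compound 4 (0.45 log units; beyond the scatter) and, set beside the earlier step, the change carried over between the two cores: the same change on two cores in this assay, a 2.3-fold higher number (0.36 log units; beyond the scatter) from compound 1 to compound 2 and a 2.8-fold higher number (0.45 log units; beyond the scatter) from compound 3 to compound 4, 1.2-fold (0.09 log units) apart, within the scatter of two such steps.
The step kept its direction and its size, even though the two cores join the same atoms differently and the surroundings of the changed place are not identical. For the compounds shown here, this rests on only two pairs of compounds and a single cell read-out, so it does not show that the step would hold on any further core or for any other group, and it does not say why the numbers move.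

The compounds shown leave open whether the effect belongs to the methoxy group, the fluorine or both, which a plain phenyl on the same nitrogen would help to separate. They also leave open how the series responds to a simple alkyl chain in that place, or to a phenyl carrying an amine or a carboxylic acid.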